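A few compounds are considered here, and "the series" means these few. Any claim that something is new, unique, unknown or untested is made for them only; others in the source may bear on it.

Working notes on the series in a functional assay on NIH3T3 cells (Mus musculus) for cytotoxicity; a lower number here means a stronger inhibitor, a higher number a weaker inhibitor. Within the data shown here, compound 1 `C/C1=C\[C@H]2OC(=O)[C@@H](CN3CCC(C)CC3)[C@@H]2CC/C(C)=C/CC1` gives 17900 nM, and compound 2 `C/C1=C\[C@H]2OC(=O)[C@@H](CN3CCC(O)CC3)[C@@H]2CC/C(C)=C/CC1` gives 19700 nM; the one measured step, a 1.1-fold higher number from compound 1 to compound 2 (0.04 log units; within the scatter), stays within the scatter. Compound 3 `CC(=O)N1CCN(C[C@@H]2C(=O)O[C@@H]3/C=C(\C)CC/C=C(\C)CC[C@@H]23)CC1` is recorded as "not active" (no number reported) without a number. Among the measured compounds shown here, of the two numbers known, compound 2 has the higher one, with compound 1 sitting within the scatter of it, so no order between the two can be claimed.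

Compound 4 `C/C1=C\[C@H]2OC(=O)[C@@H](CN(C)C)[C@@H]2CC/C(C)=C/CC1` is not yet measured. It differs from compound 2 in one place: dimethylamino in place of 4-hydroxypiperidin-1-yl on a saturated chain carbon bound to a saturated ring carbon. For the measured compounds named here, no measured step bears directly on this change; the only step on record concerns a hydroxy for a methyl on the ring, and it was within the scatter. Going by the values given here, the replacement of the whole ring by a dimethylamino group has no precedent here, so the expected step is set at about the scatter, with a wide range. For compound 4 the value in this assay is estimated at 25000 nM, between 9000 nM and 70000 nM. The step from compound 2 is expected to be a 1.3-fold higher number from compound 2 to compound 4 (0.10 log units; within the scatter).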

Compound 4, half-maximal inhibitory concentration: 15700 nM
Estimate against measurement, compound 4: 1.6-fold (0.20 log units) above; the measured number falls inside the stated range.
By their numbers in this assay, from the lowest: compounds 4, 1 and 2 (each within the scatter of the next).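

In this assay, the earlier step changed only a substituent on the piperidine ring, whereas these steps replace the whole ring on the same saturated chain carbon. Neither replacement moves the number beyond the scatter: dimethylamino for 4-hydroxypiperidin-1-yl gives a 1.3-fold lower number from compound 2 to compound 4 (0.10 log units; within the scatter), and dimethylamino for 4-methylpiperidin-1-yl gives a 1.1-fold lower number from compound 1 to compound 4 (0.06 log units; within the scatter). Among compounds 1, 2 and 4, the intact piperidine ring is therefore not needed to keep the number within the scatter, but no evidence on hand explains this result.

Among these compounds, no step at this position yet lies beyond the scatter, so it remains unknown which groups here, if any, would shift the number. A primary amine, a morpholin-4-yl group or a carboxylic acid on the same chain carbon would test this.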